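A cyclopropyl-pyridine variant on the shared oxadiazole core

The compounds below may be only part of what the source reports. "The series", "measured", "known", "first", "only" and "open" are said of these compounds alone.

Compound 2 `COc1cc(-c2noc([C@H](C)NC(=O)c3cc(C(F)(F)F)nn3C)n2)cc(C)n1` is the stronger of the two measured compounds: in an assay on T-REx-293 cells for inhibition of potassium channel subfamily T member 1 (Homo sapiens), read by patch clamp (a higher number here means a weaker inhibitor, a lower number a stronger inhibitor), compound 2 gives 505 nM, whereas compound 1 `Cc1ccnc(-c2noc([C@H](C)NC(=O)c3cc(C(F)(F)F)nn3C)n2)c1` gives 4470 nM. Within the data shown here, the single measured step, an 8.9-fold lower number from compound 1 to compound 2 (0.95 log units; beyond the scatter), exchanged one whole aryl group for another and is the only guide available.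

Compound 3 `C[C@H](NC(=O)c1cc(C(F)(F)F)nn1C)c1nc(-c2ccnc(C3CC3)c2)no1` differs from compound 2 in one place: 2-cyclopropylpyridin-4-yl in place of 2-methoxy-6-methylpyridin-4-yl on an aromatic carbon. Both the group that leaves and the group that enters contain one six-membered aromatic ring with one hetero atom, and both carry the same count of heavy atoms; what changes is the substituent pattern, with a cyclopropyl entering and a methoxy and a methyl leaving. Among the measured compounds shown here, no measured pair isolates such a substituent swap, so the size of an 8.9-fold lower number from compound 1 to compound 2 (0.95 log units; beyond the scatter) cannot be carried over directly. The expectation is therefore a step near zero beyond the scatter, with the uncertainty leaning toward a somewhat higher number. Compound 3 is estimated at 800 nM in this assay, within a range of 200 nM to 3200 nM, which means an expected step of a 1.6-fold higher number from compound 2 to compound 3 (0.20 log units; within the scatter).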

Compound 3, half-maximal inhibitory concentration in the potassium channel subfamily T member 1 assay: 16 nM
Beside the measured number, compound 3's estimate is 50-fold (1.70 log units) above it; measured number outside the range, below it.
By their numbers in the potassium channel subfamily T member 1 assay, from the lowest: compound 3; then compound 2; then compound 1.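

In the potassium channel subfamily T member 1 assay the step of a 32-fold lower number from compound 2 to compound 3 (1.50 log units; beyond the scatter) is larger than an 8.9-fold lower number from compound 1 to compound 2 (0.95 log units; beyond the scatter), and it comes from a change of substituents alone: the ring type and the count of heavy atoms stay the same, while a cyclopropyl enters and a methoxy and a methyl leave. The wider comparison, a 280-fold lower number from compound 1 to compound 3 (2.45 log units; beyond the scatter), shows how far the potency at this aromatic carbon of the five-membered ring can move with the choice of pyridinyl group. In a physicochemical assay for lipophilicity (on this read-out lower numbers stand for lower lipophilicity and higher numbers for higher lipophilicity), compound 2 gives 4.4 and compound 3 gives 4.1. In the physicochemical assay the same exchange gives a number 0.30 log units lower from compound 2 to compound 3 (within the scatter), so the large step in the potassium channel subfamily T member 1 assay has no counterpart beyond the scatter on that read-out, and no supporting measurement here accounts for the step.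

The compounds shown leave open whether the cyclopropyl itself carries the step or whether the loss of the methoxy and the methyl does, as these changes arrive together in a single exchange. They also leave open how an isopropyl or a cyclobutyl in place of the cyclopropyl, or a phenyl ring in place of the pyridine, would read in the potassium channel subfamily T member 1 assay.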